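The compounds below may be only part of what the source reports. "The series", "measured", "known", "first", "only" and "open" are said of these compounds alone.

In a functional assay on MNK45 cells (Homo sapiens) for inhibition, read by MTT assay, with a stated time of 48 h (a higher number here means a weaker inhibitor, a lower number a stronger inhibitor), compound 2 `Cc1ccc(NC(=O)NC(=O)c2ccc(OCc3cccc(C(F)(F)F)c3)cc2)cc1-c1nc2ccccc2[nH]1` gives 9600 nM. Among the values shown for this assay, this is the only one reported as a number; the single further value is a limit. Compound 1 `Cc1ccc(NC(=S)NC(=O)c2ccc(OCc3cccc(Cl)c3Cl)cc2)cc1-c1nc2ccccc2[nH]1` sits at the limit of > 100000 nM in this assay, at which 1 of the 2 values shown sits. For compound 1 the value > 100000 nM in this assay is therefore a limit and not a number. Going by the values given here, compound 1 and compound 2 differ in more than one place, so their two values show only that compound 2 has a measured number where compound 1 has none.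

Compound 3 `Cc1ccc(NC(=O)NC(=O)c2ccc(OCc3ccc(Cl)cc3Cl)cc2)cc1-c1nc2ccccc2[nH]1` has not yet been measured in this assay. It differs from compound 2 in one place: 2,4-dichlorophenyl in place of 3-(trifluoromethyl)phenyl on a saturated chain carbon bound to an oxygen on an aromatic ring. Among the compounds with values here, no step between measured compounds covers a change of this kind, so the expected size of the step must rest on the single number for compound 2 alone. The exchange of one substituted benzyl group for another at the same place is expected to shift the value by no more than the usual scatter, in no set direction. The step from compound 2 to compound 3 is therefore estimated at a 1.1-fold higher number from compound 2 to compound 3 (0.06 log units; within the scatter). In this assay compound 3 is expected to give about 11000 nM, with a range from 3500 nM to 40000 nM.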

Compound 3, half-maximal inhibitory concentration: 2550 nM
Compound 3: middle estimate off by 4.3-fold (0.63 log units), on the high side, outside the stated range (below it).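

Exchanging 3-(trifluoromethyl)phenyl for 2,4-dichlorophenyl on a saturated chain carbon bound to an oxygen on an aromatic ring gives, in this assay, a 3.8-fold lower number from compound 2 to compound 3 (0.58 log units; beyond the scatter), so the value at this place depends on which substituted phenyl group it carries. Going by these compounds alone, this is the first comparison in the set that isolates a single change, since compound 1 differs from each of the other two compounds in more than one place. Both groups count no hydrogen-bond donors or acceptors and carry no net charge, and no measured property given here accounts for the step.

On these data alone, this single step cannot separate the arrival of the two chlorine atoms from the departure of the trifluoromethyl group, and how a phenyl group bearing a methoxy group or a nitrile would read at this place remains unknown. As far as these compounds go, for compound 1, > 100000 nM is a limit and not a number, and it differs from the others in more than one place, so the effect of exchanging the carbonyl for a thiocarbonyl alone also remains open.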